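This account rests on a few compounds, and the source may have more. Where it says the series, first, only, none or still open, it means among the compounds named here.

Of the compounds shown here, two have been measured in a functional assay on SW-620 cells (Homo sapiens) for inhibition; on this read-out lower numbers stand for stronger inhibition of growth and higher numbers for weaker inhibition of growth. Compound 1 `O=C(/C=C/c1cccc(O)c1)c1cccc(-n2cc(-c3ccccc3)[nH]c2=O)c1` gives 2410 nM in this assay. Compound 2 `COc1cc(/C=C/C(=O)c2cccc(-n3cc(-c4ccccc4)[nH]c3=O)c2)cc(OC)c1OC` gives 390 nM in this assay, the lower of the two numbers; the gap from compound 1 to compound 2 lies beyond the usual scatter of repeated measurements, so compound 2 stands as the stronger inhibitor of growth of the pair.

Compound 3 `COc1cc(/C=C/C(=O)c2cccc(-n3cc(-c4cc(OC)c(OC)c(OC)c4)[nH]c3=O)c2)cc(OC)c1OC` has not yet been measured in this assay. It differs from compound 2 in one place: 3,4,5-trimethoxyphenyl in place of phenyl on an aromatic carbon. Going by the values given here, the two measured compounds give no direct precedent for a change at this position, since the difference between compound 1 and compound 2 sits on the other aromatic ring of the shared core. The step from compound 2 to compound 3 is therefore expected to be small, with a slight lean toward stronger inhibition of growth, and it may well fall within the scatter, as the expected step of a 1.3-fold lower number from compound 2 to compound 3 (0.11 log units; within the scatter) shows. Compound 3 is estimated to give 300 nM in this assay, with a range from 80 nM to 1200 nM.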

Compound 3, concentration for 50% growth inhibition: 1030 nM
Estimate against measurement, compound 3: 3.4-fold (0.54 log units) below; the measured number falls inside the stated range.
By their numbers in this assay, from the lowest: compound 2; then compound 3; then compound 1.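

Going by these compounds alone, the step of a 2.6-fold higher number from compound 2 to compound 3 (0.42 log units; beyond the scatter) in this assay is the first reading at this place, the aromatic carbon of the five-membered aromatic ring, and it shows that the group carried there affects inhibition of growth: 3,4,5-trimethoxyphenyl in place of phenyl weakens it by a margin beyond the scatter. The change is modest, however, and compound 3 still gives 1030 nM, so this position accepts the larger group of 12 heavy atoms with only a partial loss. Nothing shown accounts for the weakening, and this single step cannot say which part of the entering group is responsible.

As far as these compounds go, it remains open whether all three methoxy groups are needed for this change, since one step cannot separate them from one another, and a phenyl bearing a single methoxy group would bear on that question. Also open, from the compounds shown here alone, is how this place responds to groups of a different kind, such as a methyl group, a pyridine ring or a phenyl carrying an amine or a carboxylic acid.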